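The source may report more compounds than this note shows. Statements on the series, on what has been measured and on what is new or still open speak of the compounds shown alone.

Compound 1 `CCCN(CC[C@H]1CC[C@H](NC(=O)/C=C/c2ccc(Cl)cc2)CC1)[C@H]1CCc2nc(N)sc2C1` has been tested in an assay on brain for displacement of a labelled ligand from D(3) dopamine receptor (Rattus norvegicus) (a higher number here means a weaker inhibitor, a lower number a stronger inhibitor), where compound 1 gives 2.5 nM, the highest number among the three measured compounds. Compound 2 `CCCN(CC[C@H]1CC[C@H](NC(=O)/C=C/c2cccc(Cl)c2)CC1)[C@H]1CCc2nc(N)sc2C1` gives 1.2 nM, and compound 3 `CCCN(CC[C@H]1CC[C@H](NC(=O)c2cccc(-n3ccnc3)c2)CC1)[C@H]1CCc2nc(N)sc2C1` gives 1.1 nM. Both a 2.1-fold lower number from compound 1 to compound 2 (0.32 log units; beyond the scatter) and a 2.3-fold lower number from compound 1 to compound 3 (0.36 log units; beyond the scatter) are modest shifts toward stronger binding, while a 1.1-fold lower number from compound 2 to compound 3 (0.04 log units; within the scatter) lies within the scatter. Compound 4 `CCCN(CC[C@H]1CC[C@H](NC(=O)c2ccc(-c3noc(C)n3)cc2)CC1)[C@H]1CCc2nc(N)sc2C1` differs from compound 1 in one place: 4-(5-methyl-1,2,4-oxadiazol-3-yl)phenyl in place of 2-(4-chlorophenyl)ethenyl on a carbonyl carbon. The closest guide is a 2.3-fold lower number from compound 1 to compound 3 (0.36 log units; beyond the scatter), where the same chain with its double bond outside aromatic rings also gave way to a substituted phenyl on the carbonyl carbon. A modest lowering is therefore expected, a 1.7-fold lower number from compound 1 to compound 4 (0.22 log units; within the scatter). Compound 4 is estimated at 1.5 nM, with a range from 0.6 nM to 4 nM.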

Compound 4, inhibition constant: 1.3 nM
The estimate for compound 4 lay 1.2-fold (0.06 log units) above the measured number; low and high end bracket the measured number.
By their numbers in this assay, from the lowest: compounds 3, 2, 4 and 1 (each within the scatter of the next, the first and the last beyond it).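

Within the data shown here, on the carbonyl carbon, 4-(5-methyl-1,2,4-oxadiazol-3-yl)phenyl brings a five-membered aromatic ring with 3 hetero atoms, a kind of ring not seen in the earlier compounds, and in this assay the number stays close to all three others: a 1.9-fold lower number from compound 1 to compound 4 (0.28 log units; within the scatter) and a 1.1-fold higher number from compound 2 to compound 4 (0.03 log units; within the scatter) and a 1.2-fold higher number from compound 3 to compound 4 (0.07 log units; within the scatter) are all small steps. So this place accepts this ring too. Nothing available explains why such different groups give such close numbers.

Still open, on these data alone, is whether an aromatic ring is needed here at all, and how a carboxylic acid or an amine on the phenyl ring would fare.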